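Extending a methyl on the shared core: compound 4

The compounds below may be only part of what the source reports. "The series", "measured", "known", "first", "only" and "open" are said of these compounds alone.

Of the compounds shown here, three built on one core have been measured in an ADME assay on MDCK cells (Canis lupus familiaris) for cytotoxicity, read by MTT assay, with a stated time of 48 h; a lower number here means that less compound is tolerated, a higher number that more compound is tolerated. Compound 1 `C[C@@H]1[C@H]2C[C@@H](C[C@H]1NCc1[nH]cnc1C1CC1)C2(C)C` gives 163000 nM. Compound 2 `Cc1ncc(CN[C@@H]2C[C@@H]3C[C@H]([C@H]2C)C3(C)C)[nH]1` gives 202000 nM. Compound 3 `C[C@@H]1[C@H]2C[C@@H](C[C@H]1NCc1cnc(C(C)(C)C)[nH]1)C2(C)C` gives 107000 nM. The number for compound 2 stands together with those of compound 1 and compound 3, the gaps to both lying within the scatter, so the three are not told apart by this assay.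

Compound 4 `CCCCc1ncc(CN[C@@H]2C[C@@H]3C[C@H]([C@H]2C)C3(C)C)[nH]1` differs from compound 2 in one place: propyl in place of hydrogen on a saturated chain carbon bound to an aromatic carbon. Among the compounds with values here, of the measured steps, only the one from compound 2 to compound 3 bears on this, since it changes the same carbon in the same direction of growth: a 1.9-fold lower number from compound 2 to compound 3 (0.28 log units; within the scatter). That step stayed within the scatter, which leaves no ground for expecting a step of real size here. Growing the methyl to a butyl is therefore expected to change this assay by little, at most a mild lowering of the kind seen toward compound 3, and the step from compound 2 to compound 4 is estimated as a 1.3-fold lower number from compound 2 to compound 4 (0.13 log units; within the scatter). Compound 4 is expected to give about 150000 nM in this assay, between 60000 nM and 350000 nM.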

Compound 4, half-maximal cytotoxic concentration: 70400 nM
The estimate for compound 4 lay 2.1-fold (0.33 log units) above the measured number; measured number inside the range.
By their numbers in this assay, from the lowest: compounds 4, 3, 1 and 2 (each within the scatter of the next, the first and the last beyond it).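

In this assay, growing the methyl to a butyl on this aromatic carbon gave a 2.9-fold lower number from compound 2 to compound 4 (0.46 log units; beyond the scatter), a modest change but the only one among the steps shown at this position that lies beyond the scatter. The two larger groups are not told apart, since butyl in place of tert-butyl gave a 1.5-fold lower number from compound 3 to compound 4 (0.18 log units; within the scatter), within the scatter, while tert-butyl in place of methyl gave a 1.9-fold lower number from compound 2 to compound 3 (0.28 log units; within the scatter), also within it; the position therefore shows a real lowering only for the butyl, and only when measured against the methyl. Nothing at hand accounts for this lowering or for the butyl and tert-butyl standing together.

As far as these compounds go, whether the number keeps falling with a longer chain such as hexyl, or whether a shorter ethyl already lowers it, remains open, as three groups at this position cannot establish a trend with chain length. Also open, from the compounds shown here alone, is whether an amine or a carboxylic acid at the end of the butyl chain would bring the number back toward that of compound 2, at 202000 nM.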